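The source may report more compounds than this note shows. Statements on the series, on what has been measured and on what is new or still open speak of the compounds shown alone.

Measured compounds:
- Compound 1, `CCCn1c(=O)[nH]c2nc(-c3ccc(S(=O)(=O)N4CCN(c5ccccc5Br)CC4)cc3)[nH]c2c1=O`, in an assay on CHO cells for displacement of a labelled ligand from adenosine receptor A3 (Homo sapiens), read by scintillation counting, with a stated time of 45 min, in the presence of a further agent that is not named here (a higher number here means a weaker inhibitor, a lower number a stronger inhibitor), gives > 1000 nM, which is a limit of the assay and not a number.
- Compound 2, `CCCn1c(=O)c2[nH]c(-c3ccc(S(=O)(=O)N4CCN(c5ccc(Cl)cc5)CC4)cc3)nc2n(C)c1=O`, in this assay gives > 1000 nM, again a limit.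
- Compound 3, `CCCn1c(=O)[nH]c2nc(-c3ccc(S(=O)(=O)N4CCN(c5ccccc5)CC4)cc3)[nH]c2c1=O`, in this assay gives > 1000 nM, also a limit.

Compound 1 therefore stands only at the limit in this assay; no number is known for it, and every other value in the series sits at the same limit (the limit of > 1000 nM in this assay, at which 3 of the 3 values shown sit). Within the data shown here, the single step between measured compounds that differ in one place, a step that the two limits leave unreadable from compound 1 to compound 3, joins two limits, so its size cannot be read.

Compound 4, `CCCn1c(=O)[nH]c2nc(-c3ccc(S(=O)(=O)N4CCN(c5ccc(I)cc5)CC4)cc3)[nH]c2c1=O`, has not yet been measured in this assay. It differs from compound 1 as follows: 4-iodophenyl in place of 2-bromophenyl on an amine nitrogen in a ring. Among the measured compounds shown here, the only measured step that touches the group on the amine nitrogen in a ring is a step that the two limits leave unreadable from compound 1 to compound 3, and because of the limit of > 1000 nM in this assay, at which 3 of the 3 values shown sit, it gives no reading of direction or size. The expected step that the limit leaves unreadable from compound 1 to compound 4 therefore rests on no measured number and is expected to stay within the scatter, with compound 4 most likely also returning a limit.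

For compound 4 the estimated value in this assay is 3000 nM, with a range from 1000 nM to 10000 nM.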

Compound 4, inhibition constant: > 1000 nM
Compound 4 ended at the assay's limit; the forecaster's own chance of this, stated with the estimate: 80%; the middle value lies beyond the limit too.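

In this assay compound 4 gives > 1000 nM, a limit and not a number. The steps to compound 4 from compound 1 and compound 3 join limits and cannot be read: the limit of > 1000 nM in this assay, at which 4 of the 4 values shown sit.

The compounds shown leave open what number any of them would give in this assay, and whether the group on the amine nitrogen in a ring changes it.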